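A Trifluoromethylphenyl Variant of a Calcium Channel Inhibitor

The compounds below may be only part of what the source reports. "The series", "measured", "known", "first", "only" and "open" are said of these compounds alone.

Of the compounds shown here, two sharing one core have so far been tested in an assay on IMR-32 cells for inhibition of Voltage-dependent N-type calcium channel subunit alpha-1B (Homo sapiens), with a stated time of 5 min; a lower number here means a stronger inhibitor, a higher number a weaker inhibitor. Compound 1 `COC(OC)C1=C(C(=O)OC/C=C/c2ccccc2)C(c2cc(Cl)cc(Cl)c2)C(C(=O)O)=CN1` gives 1000 nM, and compound 2 `COc1ccc(C2C(C(=O)O)=CNC(C(OC)OC)=C2C(=O)OC/C=C/c2ccccc2)cc1Cl` gives 1500 nM. The step of a 1.5-fold higher number from compound 1 to compound 2 (0.18 log units; within the scatter) is within the scatter, so compound 2 stands at the higher of the two numbers without being separated from compound 1. Compound 3 `COC(OC)C1=C(C(=O)OC/C=C/c2ccccc2)C(c2cccc(C(F)(F)F)c2)C(C(=O)O)=CN1` differs from compound 2 in one place: 3-(trifluoromethyl)phenyl in place of 3-chloro-4-methoxyphenyl on a saturated ring carbon. Going by the values given here, only one measured step bears on this position, the step of a 1.5-fold higher number from compound 1 to compound 2 (0.18 log units; within the scatter), and it stayed within the scatter; no measured step covers a trifluoromethylphenyl group at this ring carbon. The expectation is therefore a step in this assay of no more than the scatter, in no fixed direction. Compound 3 is thus estimated to give 1200 nM, within a range from 500 nM to 3000 nM, which would be the expected step of a 1.3-fold lower number from compound 2 to compound 3 (0.10 log units; within the scatter).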

Compound 3, half-maximal inhibitory concentration: 1100 nM
For compound 3 the middle estimate is 1.1-fold (0.04 log units) above the measured one; the range from low to high includes it.
By their numbers in this assay, from the lowest: compounds 1, 3 and 2 (each within the scatter of the next).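

In this assay, 3-(trifluoromethyl)phenyl in place of 3-chloro-4-methoxyphenyl gives a 1.4-fold lower number from compound 2 to compound 3 (0.13 log units; within the scatter), and in place of 3,5-dichlorophenyl it gives a 1.1-fold higher number from compound 1 to compound 3 (0.04 log units; within the scatter). Both steps lie within the scatter, so all three substituted phenyl groups on this saturated ring carbon cannot be told apart, and this now includes a phenyl group that carries neither chlorine nor methoxy. Nothing measured here accounts for this lack of separation.

The compounds shown do not tell whether a cyclohexyl ring in place of the phenyl ring, or an amine or hydroxyl group on that phenyl ring, would also stay within the scatter. All three compounds keep the carboxy and dimethoxymethyl groups, so they say nothing about how an amide in place of the carboxy group would read.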